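This account rests on a few compounds, and the source may have more. Where it says the series, first, only, none or still open, it means among the compounds named here.

The series rests on one shared core, carried by compound 1 `Cc1cc2ccccc2nc1-c1cn(-c2ccc(F)cc2)nn1`, compound 2 `CCCCCc1cc2ccccc2nc1-c1cn(-c2ccc(F)cc2)nn1` and compound 3 `CCCc1cc2ccccc2nc1-c1cn(-c2ccc(F)cc2)nn1`, which differ only in the saturated chain attached to the aromatic carbon. In a functional assay on THP-1 cells (Homo sapiens) for cytotoxicity, read by MTT assay, with a stated time of 24 h (on this read-out lower numbers stand for stronger inhibition and higher numbers for weaker inhibition), compound 1 gives > 100 ug/mL, a limit of the assay rather than a number. Compound 2 gives > 100 ug/mL in this assay, again a limit. Compound 3 stands at > 100 ug/mL in this assay, also a limit, so its place among the three rests on the limit of > 100 ug/mL in this assay, at which 3 of the 3 values shown sit, alone. The step from compound 1 to compound 2, a step that the two limits leave unreadable from compound 1 to compound 2, the step from compound 1 to compound 3, a step that the two limits leave unreadable from compound 1 to compound 3, and the step from compound 2 to compound 3, a step that the two limits leave unreadable from compound 2 to compound 3, are all left unreadable by the limit of > 100 ug/mL in this assay, at which 3 of the 3 values shown sit.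

Compound 4 `CCCCc1cc2ccccc2nc1-c1cn(-c2ccc(F)cc2)nn1` differs from compound 3 by methyl in place of hydrogen on a saturated chain carbon, three bonds along the chain from an aromatic carbon. Each measured step ran between two limits, so none gives a readable size; yet the chains shorter and longer than that of compound 4, in compound 3 and compound 2, both sit at the limit. The estimated step that the limit leaves unreadable from compound 3 to compound 4 is therefore expected to stay within the scatter. Compound 4 is expected to give about 200 ug/mL in this assay, within 80 ug/mL to 600 ug/mL, most likely again reported only as a limit.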

Compound 4, half-maximal inhibitory concentration: 78.3 ug/mL
Compound 4: the middle estimate sits 2.6-fold (0.41 log units) above what was measured; measured number outside the range, below it.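

With compound 4, alone among the four, the saturated chain on the shared core yields a number rather than a limit in this assay, which gives the three steps a direction: an at least 1.2-fold lower number from compound 3 to compound 4 (0.10 log units; that floor lies within the scatter), an at least 1.2-fold lower number from compound 2 to compound 4 (0.10 log units; that floor lies within the scatter) and an at least 1.2-fold lower number from compound 1 to compound 4 (0.10 log units; that floor lies within the scatter). Each of these is only a floor, and each floor lies within the scatter, so methyl in place of hydrogen at this place on the chain is not shown to change the cytotoxicity read-out by more than the scatter of repeated measurements. The true size of all three steps stays unread because the other compounds carry limits: the limit of > 100 ug/mL in this assay, at which 3 of the 4 values shown sit.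

From the compounds shown here alone, whether compound 4 truly parts from the other three beyond the scatter stays open, and with compound 2, which carries a longer chain, reported only as a limit, no trend along the chain can be claimed. Also open, going by these compounds, is how a hexyl chain, a branched chain such as isobutyl, or a chain ending in an amine or a carboxylic acid would read in this assay.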